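A chloro group added to compound 2

A few compounds are considered here, and "the series" means these few. Any claim that something is new, unique, unknown or untested is made for them only; others in the source may bear on it.

In a functional assay on HeLa cells (Homo sapiens) for inhibition (on this read-out higher numbers stand for weaker inhibition and lower numbers for stronger inhibition), compound 1 (`CCN(C(=O)CC(CC(=O)NCCN1CCCC1)c1ccc(Cl)cc1)C1Cc2ccccc2C1`) gives 36400 nM as a measured number. Compound 2 (`CN(C(=O)CC(CC(=O)NCCN1CCCC1)c1ccccc1)C1Cc2ccccc2C1`) has only a limit of the assay, > 100000 nM and no exact number. Compound 3 (`CN(C(=O)CC(CC(=O)NCCN1CCCC1)c1ccc(Cl)cc1)C1Cc2ccccc2C1`) carries chloro in place of hydrogen on an aromatic carbon of compound 2 (chloro in place of hydrogen on an aromatic carbon). Within the data shown here, no measured step shows what this change does, and the only number nearby is that of compound 1 at 36400 nM in this assay for now. A modest move toward stronger inhibition is expected, with an at least 2.0-fold lower number from compound 2 to compound 3 (0.30 log units; that floor lies within the scatter) as an estimate only. Compound 3 is expected near 50000 nM with an estimated range from 20000 nM to 100000 nM in all.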

Compound 3, half-maximal inhibitory concentration: 55400 nM
Estimate against measurement, compound 3: 1.1-fold (0.04 log units) below, within the range that was stated.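

Replacing phenyl with 4-chlorophenyl gives a measured number in this assay, and the change reads as an at least 1.8-fold lower number from compound 2 to compound 3 (0.25 log units; that floor lies within the scatter). Compound 2 has only a limit of the assay, so the step has a floor and no exact size: the limit of > 100000 nM in this assay, at which 1 of the 3 values shown sits.

With 4-chlorophenyl present, hydrogen in place of methyl on the chain at the amide-type nitrogen gives a 1.5-fold higher number from compound 1 to compound 3 (0.18 log units; within the scatter), so that chain change shows no clear effect.

The compounds shown leave open how fluoro, methoxy or an amine would compare with chloro at this place. They also leave open whether a longer chain, such as propyl, on that nitrogen would change the number.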